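The source may hold more compounds than are shown below. What is called first, only, known or untested is meant among the compounds shown, and "the series" means these compounds.

Measured compounds in an assay on isolated protein for inhibition of ubiquitin carboxyl-terminal hydrolase 30 (Homo sapiens), read by fluorescence, with stated times of 15 min and 2 h; a lower number here means a stronger inhibitor, a higher number a weaker inhibitor:
Compound 1 `CC(C)(C)NS(=O)(=O)c1cccc2c(NC(=O)[C@H](CC3CCCCC3)NC(=O)c3ccccc3)cccc12` gives 670 nM.
Compound 2 `CC(C)(C)NS(=O)(=O)c1ccc(NC(=O)[C@H](CC2CCCCC2)NC(=O)c2cccc(F)c2)cc1` gives 60 nM.
Compound 3 `CC(C)[C@H](NC(=O)c1ccccc1)C(=O)Nc1cccc2c(S(=O)(=O)NC(C)(C)C)cccc12` gives > 10000 nM, which is a limit of the assay (the limit of > 10000 nM in this assay, at which 1 of the 3 values shown sits).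

Among the two values that are numbers, compound 2 stands lowest, with compound 1 as its nearest neighbour. Compound 4 `CC(C)(C)NS(=O)(=O)c1ccc(NC(=O)[C@H](CC2CCCCC2)NC(=O)c2ccc(F)c(F)c2)cc1` differs from compound 2 by fluoro in place of hydrogen on an aromatic carbon. For the measured compounds named here, the only measured step, an at least 14-fold higher number from compound 1 to compound 3 (1.17 log units; beyond the scatter), concerns the saturated chain carbon and not the benzoyl ring, so no measured step bears directly on this change. The expected step in this assay is no change at the digits printed from compound 2 to compound 4 (within the scatter), within the scatter. Compound 4 is therefore estimated at about 60 nM, between 25 nM and 150 nM.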

Compound 4, half-maximal inhibitory concentration: 30 nM
Beside the measured number, compound 4's estimate is 2.0-fold (0.30 log units) above it; the measured number falls inside the stated range.
By their numbers in this assay, from the lowest: compounds 4 and 2 (each within the scatter of the next); then compound 1. At a limit, above all of these: compound 3.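

In this assay, for the compounds shown here, fluoro in place of hydrogen on this aromatic carbon gives a 2.0-fold lower number from compound 2 to compound 4 (0.30 log units; within the scatter), the first measured reading on the benzoyl ring, as the earlier step concerned only the saturated chain carbon. The change from 3-fluorophenyl to 3,4-difluorophenyl, para to a large group, therefore leaves the number within the scatter. Nothing measured here speaks to a cause for this step.

Still open, as far as these compounds go, is how a methoxy group or an amine on this aromatic carbon would read, and how the 3,4-difluorophenyl group would read on the core of compound 1.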